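The source may hold more compounds than are shown below. What is called first, only, known or untested is meant among the compounds shown, and "the series" means these compounds.

a functional assay on MCF7 cells (Homo sapiens) for inhibition, read by MTT assay, with a stated time of 72 h (a higher number here means a weaker inhibitor, a lower number a stronger inhibitor), frames this comparison. Compound 1 `NS(=O)(=O)c1ccc2c(c1)C(=O)C(=O)N2Cc1cc(C(F)(F)F)ccc1F` gives 12000 nM in this assay, the highest of the two numbers shown, while the closest value, that of compound 3 `NS(=O)(=O)c1ccc2c(c1)C(=O)C(=O)N2Cc1c(F)c(F)c(F)c(F)c1F`, is 10200 nM in this assay, a gap that lies within the scatter. Compound 2 `NS(=O)(=O)c1ccc2c(c1)C(=O)C(=O)N2` reaches only a limit of this assay, > 50000 nM, so no number is known for it (the limit of > 50000 nM in this assay, at which 1 of the 3 values shown sits). Compound 4 `NS(=O)(=O)c1ccc2c(c1)C(=O)C(=O)N2Cc1cccc(C(F)(F)F)c1` has not yet been measured. It differs from compound 1 by hydrogen in place of fluoro on an aromatic carbon. For the measured compounds named here, no measured pair here changes only such a group, so a small step in this assay is expected, in either direction or none beyond the scatter. The estimate for compound 4 is 15000 nM, between 5000 nM and 40000 nM. The expected step is a 1.3-fold higher number from compound 1 to compound 4 (0.10 log units; within the scatter).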

Compound 4, half-maximal inhibitory concentration: 8400 nM
Estimate against measurement, compound 4: 1.8-fold (0.25 log units) above; the measured number falls inside the stated range.
By their numbers in this assay, from the lowest: compounds 4, 3 and 1 (each within the scatter of the next). At a limit, above all of these: compound 2.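

For the compounds shown here, replacing fluoro with hydrogen on this aromatic carbon, para to a trifluoromethyl group, gives the first comparison in this assay of compounds that differ in one place: a 1.4-fold lower number from compound 1 to compound 4 (0.15 log units; within the scatter). At this position, then, the fluoro can be lost with no change that stands out from the scatter. Nothing measured here bears on why this step is so small. On these data alone, whether an amine or a methoxy group on this carbon would shift the number stays open, and so does the effect of a carboxylic acid in place of the trifluoromethyl group.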